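The compounds below may be only part of what the source reports. "The series", "measured", "known", "first", "only" and "open" are said of these compounds alone.

Compound 1 `CC(C)N(Cc1cccc(OCCCCCC(=O)O)c1)C(=O)c1ccc(-c2ccncc2)cc1` gives > 26000 nM

Compound 2 `CC(C)N(Cc1cccc(OCCCCCC(=O)O)c1)C(=O)c1ccc(-c2cccc(O)c2)cc1` gives > 26000 nM

Compound 3 `CC(C)N(Cc1cccc(OCCCCCC(=O)O)c1)C(=O)c1ccc(-c2c[nH]c3ccccc23)cc1` gives > 26000 nM

In an ADME assay on HepG2 cells (Homo sapiens) for cytotoxicity, read by CellTiter-Glo and resazurin assay, with a stated time of 72 h (a lower number here means that less compound is needed, a higher number that more compound is needed for the effect), compound 3 gives > 26000 nM as a limit, not a number. Compound 3 therefore stands at the limit of > 26000 nM in this assay, at which 3 of the 3 values shown sit, and has no readable rank among the three.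

The change to compound 4 `CC(C)N(Cc1cccc(OCCCCCC(=O)O)c1)C(=O)c1ccc(-c2cccc(F)c2)cc1` is 3-fluorophenyl in place of 1H-indol-3-yl on an aromatic carbon on an aromatic carbon, para to a large group. Within the data shown here, at that same place the data hold a step that the two limits leave unreadable from compound 1 to compound 2 and a step that the two limits leave unreadable from compound 1 to compound 3 and also a step that the two limits leave unreadable from compound 2 to compound 3 as the only guides. Among the measured compounds shown here, none has a readable size, so they point to no expected step in this assay in either direction.

The expected result is a step that the limit leaves unreadable from compound 3 to compound 4 and nothing beyond the scatter. Compound 4 is estimated at 30000 nM within a range of 13000 nM to 60000 nM and will most likely be reported as another limit.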

Compound 4, half-maximal effective concentration: > 26000 nM
Compound 4 gave a limit, no number (the forecaster's own chance of this, stated with the estimate: 85%); the middle value lies beyond the limit too.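

Among these compounds, compound 4 also gives only a limit, so no step from compound 1, compound 2 or compound 3 to compound 4 can be read: the limit of > 26000 nM in this assay, at which 4 of the 4 values shown sit. The compounds shown leave open whether swapping this group changes cytotoxicity at all.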